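A few compounds are considered here, and "the series" means these few. Any claim that something is new, unique, unknown or untested is made for them only; others in the source may bear on it.

Among the compounds with values here, compound 3 `CCCOC(=O)C1=C(C)N(C)C(=O)NC1c1cccs1` is one of three compounds measured in an assay on membranes from HEK293 cells for displacement of a labelled ligand from adenosine receptor A2b (Homo sapiens), read by scintillation counting, with a stated time of 30 min, tested at 1 uM; on this read-out higher numbers stand for more inhibition at the one concentration tested (going by the name of the read-out) and lower numbers for less inhibition. In this assay compound 3 gives 1%, the lowest of the three numbers. Compound 2 `CC1=C(C(=O)OC(C)(C)C)C(c2ccco2)NC(=O)N1C` stands nearest to it: in this assay compound 2 gives 26%, a number that lies beyond the scatter above compound 3. Compound 1 `CC1=C(C(=O)OC(C)(C)C)C(c2cccs2)NC(=O)N1` stands furthest away: in this assay compound 1 gives 38%, again beyond the scatter above compound 3. Within the data shown here, neither compound 1 nor compound 2 differs from compound 3 in a single place, so no single step between measured compounds can be read from these numbers.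

Compound 4 `CC1=C(C(=O)OC(C)(C)C)C(c2cccs2)NC(=O)N1C` has not been measured. It differs from compound 3 in one place: tert-butyl in place of propyl on an oxygen next to a carbonyl group. Compound 4 shares its tert-butyl ester with compound 1 and compound 2, both of which sit well above compound 3 in this assay, while it shares the methyl on the ring nitrogen with compound 2 and compound 3. On that basis compound 4 is expected to move upward from compound 3 by a step of a number 26 percentage points higher from compound 3 to compound 4 (beyond the scatter), a change beyond the scatter. In this assay compound 4 is therefore estimated at 27%, with a likely range from 10% to 42%.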

Compound 4, a percentage reported as inhibition, at one concentration (the size of the read-out at that concentration, not a potency): 24%
The estimate for compound 4 lay 3 percentage points above the measured number, and the stated range covers the measured number.
By their numbers in this assay, from the lowest: compound 3; then compounds 4 and 2 (each within the scatter of the next); then compound 1.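

Read in this assay, tert-butyl in place of propyl on an oxygen next to a carbonyl group gives a number 23 percentage points higher from compound 3 to compound 4 (beyond the scatter) as the first reading of this position with everything else in the structure held fixed, so the change alone is enough to carry a step beyond the scatter. The other two single changes now also have a size: thiophen-2-yl in place of furan-2-yl on a saturated ring carbon gives a number 2 percentage points lower from compound 2 to compound 4 (within the scatter) and stays within the scatter, so this swap shows no difference here. Methyl in place of hydrogen on an amide-type nitrogen in a ring gives a number 14 percentage points lower from compound 1 to compound 4 (beyond the scatter) and lies beyond the scatter, which shows that the tert-butyl ester does not fix the number by itself.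

Going by these compounds, how an ethyl, an isopropyl, a longer chain such as butyl, or a carboxylic acid in place of the ester would read at this position stays open, as does whether the step from propyl to tert-butyl keeps its size with hydrogen on the ring nitrogen. Nothing available explains any of these steps.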